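Ortho substituent swap on a thiosemicarbazone scaffold

The source may hold more compounds than are shown below. What is called first, only, known or untested is meant among the compounds shown, and "the series" means these compounds.

Measured compounds:
compound 1 `C/C(=N\NC(=S)Nc1ccccc1Cl)c1ccccn1`, 2.6 nM
compound 2 `C/C(=N/NC(=S)Nc1ccccc1[N+](=O)[O-])c1ccccn1`, 4.3 nM
compound 3 `C/C(=N\NC(=S)Nc1ccccc1[N+](=O)[O-])c1ccccn1`, 4.3 nM

In a functional assay on U-87MG ATCC cells (Homo sapiens) for cytotoxicity, read by MTT assay, with a stated time of 48 h (a lower number here means a stronger inhibitor, a higher number a weaker inhibitor), compound 3 gives 4.3 nM and compound 1 gives 2.6 nM. The change between them is chloro in place of nitro on an aromatic carbon, and the step is a 1.7-fold lower number from compound 3 to compound 1 (0.22 log units; within the scatter). Compound 2 and compound 3 differ as the two compounds have the same atoms and bonds and differ only in configuration as drawn: 1 of 1 stereo elements differ; a double bond is drawn E in compound 3 and Z in compound 2; the step of no change at the digits printed from compound 2 to compound 3 (within the scatter) is unchanged, consistent with the fact that compounds 2 and 3 differ only in the configuration as drawn. Compound 4 `C/C(=N/NC(=S)Nc1ccccc1Cl)c1ccccn1` is not yet measured. It differs from compound 2 as chloro in place of nitro on an aromatic carbon, the same change, at the same place, as that from compound 3 to compound 1. Resting on compound 2 at 4.3 nM and on the earlier step of a 1.7-fold lower number from compound 3 to compound 1 (0.22 log units; within the scatter), the expected step is a 1.7-fold lower number from compound 2 to compound 4 (0.22 log units; within the scatter). Compound 4 is therefore estimated at 2.6 nM, between 1.3 nM and 5.2 nM, in this assay.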

Compound 4, half-maximal inhibitory concentration: 2.6 nM
Compound 4: the middle estimate sits on the measured number at the digits printed; the range from low to high includes it.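

In this assay, chloro in place of nitro gives a 1.7-fold lower number from compound 2 to compound 4 (0.22 log units; within the scatter), and the change reads the same on both drawn forms of the core: the same change on two cores in this assay, a 1.7-fold lower number (0.22 log units; within the scatter) from compound 3 to compound 1 and a 1.7-fold lower number (0.22 log units; within the scatter) from compound 2 to compound 4, 1.0-fold (0.00 log units) apart, within the scatter of two such steps. The two chloro compounds also stand together, with no change at the digits printed from compound 1 to compound 4 (within the scatter), and the only difference between them is that of the double bond as drawn: the fact that compounds 1 and 4 differ only in the configuration as drawn. This shows that the swap carries across these two forms, but with both steps within the scatter, it does not show that chloro and nitro differ here, or that the step would hold on a core changed in any other way.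

The compounds shown leave open how a methyl, a methoxy or an amine would read in place of chloro or nitro. They also leave open whether either group would give the same number elsewhere on the aromatic ring.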